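The compounds below may be only part of what the source reports. "The series", "measured", "known", "first", "only" and "open" are said of these compounds alone.

Compound 2, `Cc1ccc(CSc2n[nH]c(-n3[se]c4ccccc4c3=O)n2)cc1`, is known only through a limit: in a functional assay on A549 cells (Homo sapiens) for antiproliferative activity, read by CCK-8 assay, with a stated time of 48 h (on this read-out lower numbers stand for stronger inhibition and higher numbers for weaker inhibition), compound 2 gives > 50000 nM, which is the limit of the assay and not a number. Compound 1, `CCSc1n[nH]c(-n2[se]c3ccccc3c2=O)n1`, differs from it in one place, and in this assay compound 1 gives 39600 nM. The step of an at least 1.2-fold higher number from compound 1 to compound 2 (0.10 log units; that floor lies within the scatter) covers a 4-methylphenyl in place of methyl on a saturated chain carbon bound to a sulfur, and its floor, set by the limit of > 50000 nM in this assay, at which 1 of the 2 values shown sits, lies within the usual scatter of repeated measurements. Compound 3, `O=c1c2ccccc2[se]n1-c1nc(SCc2ccc(Cl)cc2)n[nH]1`, is not yet measured; it differs from compound 2 by chloro in place of methyl on an aromatic carbon, read one bond further out as 4-methylbenzyl to 4-chlorobenzyl. Within the data shown here, no measured step touches this aromatic carbon, so the only guidance is that compound 2 already sits at the limit and the one measured step did not move far. A step that the limit leaves unreadable from compound 2 to compound 3 is expected, meaning nothing beyond the scatter in this assay. Compound 3 is therefore estimated at 55000 nM, within 20000 nM to 150000 nM, and the assay may again report only a limit.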

Compound 3, half-maximal inhibitory concentration: 42100 nM
For compound 3 the middle estimate is 1.3-fold (0.12 log units) above the measured one; low and high end bracket the measured number.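

With 4-chlorobenzyl in place of 4-methylbenzyl, the series gains its first measured number for a large aromatic group on the sulfur, where compound 2 offers only a limit. Set against the small ethyl chain end of compound 1, this result gives a 1.1-fold higher number from compound 1 to compound 3 (0.03 log units; within the scatter), so in this assay these two compounds cannot be told apart, and swapping that small end for the 4-chlorobenzyl group has no readable effect on the number. The chloro for methyl change on the aromatic carbon can be read only in part, as an at least 1.1-fold lower number from compound 2 to compound 3 (0.07 log units; that floor lies within the scatter), and its true size stays open, as one end of this step is a limit and not a number: the limit of > 50000 nM in this assay, at which 1 of the 3 values shown sits.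

The compounds shown leave open whether any other group at this aromatic carbon, such as a methoxy group, a nitrile or an amine, would move the number beyond the scatter. They also leave open whether a longer chain or a carboxylic acid on the sulfur side, or a change in the shared core, would bring a clearly lower number.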